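The source may hold more compounds than are shown below. What is called first, only, known or untested is meant among the compounds shown, and "the series" means these compounds.

Compound 1 `O=C(NCCCCc1ccccc1)n1c(=O)oc2ccc(Cl)cc21` is the reference point here. In an assay on HEK293 cells for inhibition of acid ceramidase (Homo sapiens), with a stated time of 10 min (a lower number here means a stronger inhibitor, a higher number a weaker inhibitor), compound 1 gives 15 nM. Compound 3 `O=C(NCCCCc1ccccc1)n1c(=O)oc2cc(Cl)c(Cl)cc21` gives 18 nM, and the two are separated only by a 1.2-fold higher number from compound 1 to compound 3 (0.08 log units; within the scatter). Among the compounds with values here, compound 2 `O=C(NCCCCCc1ccccc1)n1c(=O)oc2ccccc21` gives 54 nM, which lies beyond the scatter from compound 1, though no single-point step links these two. Compound 4 `COc1ccc(-c2ccc3oc(=O)n(C(=O)NCCCCc4ccccc4)c3c2)cc1` differs from compound 1 by 4-methoxyphenyl in place of chloro on an aromatic carbon. Within the data shown here, the only measured step on the core, a 1.2-fold higher number from compound 1 to compound 3 (0.08 log units; within the scatter), added a chloro and moved nothing beyond the scatter; no measured step exchanges chloro for an aryl group, so it bears on the present change only loosely. The step of a 1.5-fold higher number from compound 1 to compound 4 (0.17 log units; within the scatter) is therefore expected to be modest, with no clear direction. The estimate for compound 4 is 22 nM, with a range from 7 nM to 70 nM.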

Compound 4, half-maximal inhibitory concentration: 67 nM
Beside the measured number, compound 4's estimate is 3.0-fold (0.48 log units) below it; the measured number falls inside the stated range.
By their numbers in this assay, from the lowest: compounds 1 and 3 (each within the scatter of the next); then compounds 2 and 4 (each within the scatter of the next).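

Exchanging chloro for 4-methoxyphenyl on this aromatic carbon gives a 4.5-fold higher number from compound 1 to compound 4 (0.65 log units; beyond the scatter), so the change weakens inhibition, yet compound 4 keeps a nanomolar value. The only earlier step on the core, a 1.2-fold higher number from compound 1 to compound 3 (0.08 log units; within the scatter), stayed within the scatter, so this is the first change on the core shown to move the number beyond it. No measurement at hand accounts for this loss. As far as these compounds go, it remains open whether plain phenyl, without the methoxy, or a smaller group such as methyl at this place would stay level with compound 1.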